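The source may report more compounds than this note shows. Statements on the series, on what has been measured and on what is new or still open speak of the compounds shown alone.

Measured in a functional assay on OVCAR-3 cells (Homo sapiens) for inhibition, read by sulforhodamine B assay, with a stated time of 48 h; on this read-out lower numbers stand for stronger inhibition of growth and higher numbers for weaker inhibition of growth:
- Compound 1 `CN(C)/C=C/C(=O)c1nn(-c2ccccc2)c(-c2ccccc2)c1C#N`: 98800 nM
- Compound 2 `Cc1nnc(-c2nn(-c3ccccc3)c(-c3ccccc3)c2C#N)c2cn(-c3ccccc3)nc12`: 96800 nM
- Compound 3 `N#Cc1c(-c2nnc(O)c3nn(-c4ccccc4)cc23)nn(-c2ccccc2)c1-c1ccccc1`: > 100000 nM (a limit)

Compound 3 stands at the limit of > 100000 nM in this assay, at which 1 of the 3 values shown sits, so its place is a limit and not a number. Compound 4 `N#Cc1c(-c2nnc(O)c3nn(-c4ccc(Cl)cc4)cc23)nn(-c2ccccc2)c1-c1ccccc1` is phenyl to 4-chlorophenyl: chloro in place of hydrogen on an aromatic carbon, para to a large group (chloro in place of hydrogen on an aromatic carbon). Among the measured compounds shown here, the only measured step is an at least 1.0-fold higher number from compound 2 to compound 3 (0.01 log units; that floor lies within the scatter), with hydroxy in place of methyl on an aromatic carbon. For the measured compounds named here, that is a different change, and no measured step tests chloro. No shift beyond the scatter is therefore expected in this assay. The expected size is an at least 1.2-fold lower number from compound 3 to compound 4 (0.09 log units; that floor lies within the scatter). For compound 4 the estimate is 80000 nM, with an expected range of 30000 nM to 120000 nM.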

Compound 4, concentration for 50% growth inhibition: 33400 nM
Compound 4: the middle estimate sits 2.4-fold (0.38 log units) above what was measured, within the range that was stated.
By their numbers in this assay, from the lowest: compound 4; then compounds 2 and 1 (each within the scatter of the next). At a limit, above all of these: compound 3.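

In this assay, phenyl to 4-chlorophenyl gives the only step beyond the scatter among these compounds: an at least 2.9-fold lower number from compound 3 to compound 4 (0.47 log units; beyond the scatter). This shows that one chlorine atom at this place, para to a large group, can move the growth read-out, which the earlier step with hydroxy in place of methyl could not show. Compound 3 stands at a limit, so this step has a floor and no exact size: the limit of > 100000 nM in this assay, at which 1 of the 4 values shown sits. Going by these compounds, whether a methoxy group or an amine at the same place would also lower the number stays open.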